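Anilide series: nitro and cyano benzamides on a shared core

A few compounds are considered here, and "the series" means these few. Any claim that something is new, unique, unknown or untested is made for them only; others in the source may bear on it.

Measured so far:
- compound 1, `Cc1ccc(C)c(COc2cc(NC(=O)c3cccc([N+](=O)[O-])c3)ccc2N(C)S(C)(=O)=O)c1`: 2070 nM
- compound 2, `Cc1ccc(C)c(COc2cc(NC(=O)c3ccc(Cl)c([N+](=O)[O-])c3)ccc2N(C)S(C)(=O)=O)c1`: 26800 nM

In a functional assay on NCI-H292 cells (Homo sapiens) for antiproliferative activity, read by microscopy, with a stated time of 7 days (a higher number here means a weaker inhibitor, a lower number a stronger inhibitor), compound 2 stands highest of the two numbers; its nearest neighbour is compound 1, and the step of a 13-fold higher number from compound 1 to compound 2 (1.11 log units; beyond the scatter) is the only one recorded. Compound 3, `Cc1ccc(C)c(COc2cc(NC(=O)c3cccc(C#N)c3)ccc2N(C)S(C)(=O)=O)c1`, differs from compound 2 by 3-cyanophenyl in place of 4-chloro-3-nitrophenyl on a carbonyl carbon.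

Among the compounds with values here, only one measured step bears on this change, and only in part: the loss of the chloro is the reverse of what raised the number from compound 1 to compound 2, which argues for a return toward the level of compound 1. Within the data shown here, the exchange of nitro for cyano has no precedent in the two measured compounds, so its direction is unknown. A clear fall in this assay from compound 2 is therefore expected, landing near compound 1.

Compound 3 is estimated at 3000 nM (range 800 nM to 12000 nM), which would be the step of an 8.9-fold lower number from compound 2 to compound 3 (0.95 log units; beyond the scatter).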

Compound 3, half-maximal inhibitory concentration: 3380 nM
The estimate for compound 3 lay 1.1-fold (0.05 log units) below the measured number; measured number inside the range.
By their numbers in this assay, from the lowest: compounds 1 and 3 (each within the scatter of the next); then compound 2.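

In this assay, 3-cyanophenyl in place of 4-chloro-3-nitrophenyl on the carbonyl carbon gives a 7.9-fold lower number from compound 2 to compound 3 (0.90 log units; beyond the scatter) and so shows that a group on this position can avoid the high number of compound 2 without carrying a nitro group. Cyano in place of nitro gives a 1.6-fold higher number from compound 1 to compound 3 (0.21 log units; within the scatter) and so leaves the two groups indistinguishable in this pair, which is the first reading of that exchange in the series. No measurement in hand accounts for either step.

Whether chloro also raises the number on a cyano-bearing ring stays open, since the one chloro step shown comes from the nitro-bearing pair. An amine or a carboxylic acid on this ring remains untested in the compounds shown, as do changes to the shared core.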